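Benzothiazole-amide series: cytotoxicity on WI-38 VA13 cells

A few compounds are considered here, and "the series" means these few. Any claim that something is new, unique, unknown or untested is made for them only; others in the source may bear on it.

Measured so far:
compound 1 `O=C(Nc1ccc2nc(NC(=O)C3CCCCC3)sc2c1)c1ccccc1Oc1ccccc1`: 0.1 ug/mL
compound 2 `O=C(Nc1ccc2nc(NC(=O)C3CCCCC3)sc2c1)c1c(Cl)cccc1Cl`: 0.015 ug/mL

In a functional assay on WI-38 VA13 cells (Homo sapiens) for cytotoxicity (a lower number here means that less compound is needed, a higher number that more compound is needed for the effect), compound 2 stands lowest of the two numbers in hand; the nearest is compound 1, whose value is higher by a margin beyond the usual scatter. Within the data shown here, no step between measured compounds that differ in one place is available, so the move to compound 3 `Cc1cccc(C)c1NC(=O)Nc1ccc2nc(NC(=O)C3CCCCC3)sc2c1` rests on the structural change alone: (2,6-dimethylphenyl)amino in place of 2,6-dichlorophenyl on a carbonyl carbon. This exchanges one aryl amide terminus for an aryl urea terminus on the shared core. With compound 1 as the only other point and its number lying above that of compound 2, a moderate rise in the value is expected rather than a fall, though the change is without precedent here and the step could also stay within the scatter. For compound 3 the estimated result in this assay is 0.05 ug/mL, with a range of 0.012 ug/mL to 0.25 ug/mL, which means an expected step of a 3.3-fold higher number from compound 2 to compound 3 (0.52 log units; beyond the scatter).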

Compound 3, half-maximal effective concentration: 0.56 ug/mL
Compound 3: middle estimate off by 11-fold (1.05 log units), on the low side; measured number outside the range, above it.
By their numbers in this assay, from the lowest: compound 2; then compound 1; then compound 3.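

In this assay the group on this carbonyl carbon sets the number strongly: (2,6-dimethylphenyl)amino in place of 2,6-dichlorophenyl gives a 37-fold higher number from compound 2 to compound 3 (1.57 log units; beyond the scatter), which makes compound 3 the highest of the three. The exchange alters two things at once, adding a nitrogen with its hydrogen-bond donor and replacing chlorine with methyl on the aromatic ring, so the step cannot be divided between them. Nothing available bears on why the number rises.

Open, as far as these compounds go, is which of the two alterations carries the step: (2,6-dichlorophenyl)amino or 2,6-dimethylphenyl on the same carbonyl carbon would separate them. Also open, from the compounds shown here alone, is how the number responds to a plain phenyl or a morpholine group on that carbon.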